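A few compounds are considered here, and "the series" means these few. Any claim that something is new, unique, unknown or untested is made for them only; others in the source may bear on it.

Compound 3 `CCC[C@@H](CCn1cncn1)c1ccc(F)cc1` belongs to a small set examined in an ADME assay on RD cells (Homo sapiens) for cytotoxicity, read by MTT assay, with a stated time of 3 days; a higher number here means that more compound is tolerated, a lower number that less compound is tolerated. In this assay compound 3 gives 56.9 ug/mL. Its two companions are compound 1 `CC[C@@H](CCn1cncn1)c1ccc(Cl)cc1`, which gives 55.3 ug/mL, and compound 2 `CCC[C@H](CCn1cncn1)c1ccc(F)cc1`, which gives 38.4 ug/mL. All three numbers lie within the usual scatter of one another, so none of the three can be said to be tolerated better or worse than the others.

Compound 4 `CCC[C@@H](CCn1cncn1)c1ccc(Cl)cc1` has not yet been measured. It differs from compound 3 by chloro in place of fluoro on an aromatic carbon. For the measured compounds named here, the only measured step that involves a single change is a 1.5-fold higher number from compound 2 to compound 3 (0.17 log units; within the scatter), which rests on the fact that compounds 2 and 3 differ only in the configuration as drawn and therefore says nothing about putting chloro in place of fluoro. Compound 1 carries chloro and compound 3 carries fluoro, but the two also differ elsewhere in their structures, so their values cannot be read as a chloro-for-fluoro step on their own; they do show that a chloro-bearing compound and a fluoro-bearing compound can give numbers within the scatter of each other. On this basis no step beyond the scatter is expected from compound 3 to compound 4, that is a 1.1-fold lower number from compound 3 to compound 4 (0.06 log units; within the scatter). Compound 4 is therefore estimated at 50 ug/mL, with a likely range from 25 ug/mL to 100 ug/mL.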

Compound 4, half-maximal cytotoxic concentration: 40.8 ug/mL
Estimate against measurement, compound 4: 1.2-fold (0.09 log units) above, within the range that was stated.
By their numbers in this assay, from the lowest: compounds 2, 4, 1 and 3 (each within the scatter of the next).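

For the compounds shown here, for the first time, a single change at this position can be read in this assay: on an aromatic carbon para to a large group, chloro in place of fluoro gives a 1.4-fold lower number from compound 3 to compound 4 (0.14 log units; within the scatter), so the two halogens cannot be told apart here. Compound 4 also allows a second single-place comparison on the saturated chain, where methyl in place of hydrogen, three bonds along the chain from an aromatic carbon, gives a 1.4-fold lower number from compound 1 to compound 4 (0.13 log units; within the scatter), and this difference is also too small to separate from ordinary repeat-to-repeat variation. Nothing available about these compounds offers an explanation for either result.

On these data alone, only chloro and fluoro appear at this aromatic carbon, so it remains open whether an amine, a carboxylic acid or a methoxy group there would give a number clearly different from these. Also open, as far as these compounds go, are how a longer chain would compare in this cell test and whether the opposite drawn configuration of compound 4 would give a number within the scatter of its own.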